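The compounds below may be only part of what the source reports. "The series", "measured", "known", "first", "only" and "open" are said of these compounds alone.

Measured in a functional assay on K562 cells (Homo sapiens) for cytotoxicity, read by sulforhodamine B assay; on this read-out lower numbers stand for stronger inhibition of growth and higher numbers for weaker inhibition of growth:
- compound 1 `CC1=CC[C@@H]([C@@](C)(O)CCCC(C)(C)NC(=S)NN)CC1`: 20 nM
- compound 2 `CC1=CC[C@@H]([C@@](C)(O)CCCC(C)(C)NC(=S)N/N=C\c2cccc([N+](=O)[O-])c2)CC1`: 20 nM
- compound 3 `CC1=CC[C@@H]([C@@](C)(O)CCCC(C)(C)NC(=S)N/N=C\c2ccc([N+](=O)[O-])cc2)CC1`: 4220 nM

At 4220 nM, compound 3 has the highest of the three numbers. Compound 4 `CC1=CC[C@@H]([C@@](C)(O)CCCC(C)(C)NC(=S)N/N=C\c2cccc(Cl)c2)CC1` differs from it as follows: 3-chlorophenyl in place of 4-nitrophenyl on a carbon with a double bond to nitrogen. It thus has 3-chlorophenyl in place of 4-nitrophenyl on a carbon with a double bond to nitrogen. Within the data shown here, one measured step bears on this change: a 210-fold higher number from compound 2 to compound 3 (2.32 log units; beyond the scatter), with 4-nitrophenyl in place of 3-nitrophenyl. Among the measured compounds shown here, no compound with a chlorine has been measured, so the transfer from 3-nitrophenyl to 3-chlorophenyl is uncertain. A large step towards a lower number in this assay is nevertheless expected, though perhaps not the full size of that measured step. The expected change is an 84-fold lower number from compound 3 to compound 4 (1.93 log units; beyond the scatter). Compound 4 is estimated at 50 nM, within an expected range from 12 nM to 400 nM.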

Compound 4, concentration for 50% growth inhibition: 30 nM
Beside the measured number, compound 4's estimate is 1.7-fold (0.22 log units) above it; the measured number falls inside the stated range.
By their numbers in this assay, from the lowest: compounds 1, 2 and 4 (each within the scatter of the next); then compound 3.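

In this assay the 3-chlorophenyl group recovers what the 4-nitrophenyl group gave up, with a 140-fold lower number from compound 3 to compound 4 (2.15 log units; beyond the scatter) in this change. Chloro in place of nitro on an aromatic carbon gives a 1.5-fold higher number from compound 2 to compound 4 (0.18 log units; within the scatter) and so shows that a nitro group is not required for a low number here. The whole 3-chlorophenyl hydrazone end gives a 1.5-fold higher number from compound 1 to compound 4 (0.18 log units; within the scatter) and thus stands level with the simpler compound. From the compounds shown here alone, it remains open whether a 4-chlorophenyl group would track compound 3 or compound 4, which would separate the ring place from the nitro group. Nothing measured here explains these differences.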